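The source may hold more compounds than are shown below. What is called first, only, known or untested is meant among the compounds shown, and "the series" means these compounds.

Compound 1 `CC1=NNC(=O)C1C(c1c(-c2ccccc2)[nH]c2ccc(Cl)cc12)c1c(-c2ccccc2)[nH]c2ccc(Cl)cc12` gives 14600 nM in a functional assay on HEp-2 cells (Homo sapiens) for cytotoxicity, read by MTT assay; a higher number here means a weaker inhibitor, a lower number a stronger inhibitor.
Compound 2 `COc1ccc2[nH]c(-c3ccccc3)c(C(c3c(-c4ccccc4)[nH]c4ccc(Cl)cc34)C3C(=O)NN=C3C)c2c1` gives 6200 nM.
Compound 3 `CC1=NNC(=O)C1C(c1c[nH]c2ccccc12)c1c(-c2ccccc2)[nH]c2ccc(Cl)cc12` gives only a limit of the assay, > 100000 nM.

Compound 1 and compound 2 share a core and differ in one place: methoxy in place of chloro on an aromatic carbon. That change gave a 2.4-fold lower number from compound 1 to compound 2 (0.37 log units; beyond the scatter). Compound 3 carries a different core; the difference between the two cores is not broken down here. Compound 4 `COc1ccc2[nH]c(-c3ccccc3)c(C(c3c[nH]c4ccccc34)C3C(=O)NN=C3C)c2c1` has not been measured and differs from compound 3 by methoxy in place of chloro on an aromatic carbon, the same change, at the same place. Because compound 3 sits at the limit (the limit of > 100000 nM in this assay, at which 1 of the 3 values shown sits), any step from it can only be read against that limit. Compound 4 is expected to show a number no higher from compound 3 to compound 4 (the limit leaves the size open), resting on a 2.4-fold lower number from compound 1 to compound 2 (0.37 log units; beyond the scatter). The estimate for compound 4 is 100000 nM, between 40000 nM and 250000 nM, with a real chance that only a limit is reported again.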

Compound 4, half-maximal inhibitory concentration: 5300 nM
Estimate against measurement, compound 4: 19-fold (1.28 log units) above; the whole stated range lies above it.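

In this assay, methoxy in place of chloro gave an at least 18-fold lower number from compound 3 to compound 4 (1.27 log units; beyond the scatter), so the change lowers the number on both cores, but not by a similar amount: the same change on two cores in this assay, a 2.4-fold lower number (0.37 log units; beyond the scatter) from compound 1 to compound 2 and an at least 18-fold lower number (1.27 log units; beyond the scatter) from compound 3 to compound 4, at least 8.0-fold (0.90 log units) apart, beyond the scatter of two such steps. As far as these compounds go, compound 3 has only a limit of the assay, > 100000 nM, so the full size of its step stays unknown. The direction of the change carried over between these two cores while its size did not, and two pairs cannot show what sets that size or how the change would behave on any other core in the series.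

The compounds shown leave open what an amine or a longer chain such as ethoxy would do at this place on either core.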